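The source may report more compounds than this note shows. Statements on the series, on what has been measured and on what is new or still open speak of the compounds shown alone.

Three esters sharing one core have been measured so far. In a functional assay on the whole organism (strain Kunming) with Mus musculus as the target, with a stated time of 0.5 h, at a dose of 300 mg/kg by the intraperitoneal route (on this read-out lower numbers stand for a stronger effect and higher numbers for a weaker effect at the one dose given), compound 1 `COc1cc(OC)c(OC)cc1/C=C/COC(=O)/C=C/c1ccc(OC)c(OC)c1` gives 75%. Compound 2 `COc1cc(OC)c(OC)cc1/C=C/COC(=O)/C=C/c1ccc(Br)cc1` gives 75% in this assay. Compound 3 `COc1cc(OC)c(OC)cc1/C=C/COC(=O)/C=C/c1ccccc1C(F)(F)F` gives 75% in this assay, standing level with compounds 1 and 2 at the digits shown. The three steps among them all exchange the aryl group on a double-bonded chain carbon bound to a double-bonded chain carbon: no change at the digits printed from compound 1 to compound 2 (within the scatter), no change at the digits printed from compound 1 to compound 3 (within the scatter) and no change at the digits printed from compound 2 to compound 3 (within the scatter). None of them moved the read-out beyond the scatter.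

Compound 4 `COc1cc(OC)c(OC)cc1/C=C/COC(=O)/C=C/c1ccc(F)cc1` has not yet been measured. It differs from compound 3 in the same place: 4-fluorophenyl in place of 2-(trifluoromethyl)phenyl on a double-bonded chain carbon bound to a double-bonded chain carbon. Every measured step bearing on this position was flat, so no step beyond the scatter is expected in this assay for compound 4 either. Compound 4 is therefore expected to give about 75% in this assay, with a range from 60% to 90%. The expected step is no change at the digits printed from compound 3 to compound 4 (within the scatter).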

Compound 4, a percentage reported as activity, at one dose (the size of the read-out at that dose, not a potency): 75%
Compound 4: the middle estimate sits on the measured number at the digits printed; the range from low to high includes it.
By their numbers in this assay, from the lowest: compounds 1, 2, 3 and 4 (each within the scatter of the next).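

In this assay, the 4-fluorophenyl, with fewer heavy atoms, replaces the 2-(trifluoromethyl)phenyl, and the result is no change at the digits printed from compound 3 to compound 4 (within the scatter), so the flat picture at this position now extends to this smaller aryl group. Going by these compounds alone, the first step confined to a single atom, fluoro in place of bromo on an aromatic carbon, gives no change at the digits printed from compound 2 to compound 4 (within the scatter), and the exchange for the 3,4-dimethoxyphenyl gives no change at the digits printed from compound 1 to compound 4 (within the scatter), so all four aryl groups read alike at the one dose given. Nothing available accounts for this flat result.

The compounds shown leave open whether an amine or a carboxylic acid on this aromatic ring would move the read-out beyond the scatter. They also leave open whether an amide in place of the ester, or a longer chain, would do so.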